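Removing an ethyl from the core of compound 1

The source may report more compounds than this note shows. Statements on the series, on what has been measured and on what is new or still open speak of the compounds shown alone.

Measured so far:
compound 1 `CCN(CC)CCCC(C)Nc1nc(NCc2ccc(Cl)cc2Cl)nc2ncn(CC)c12` 2600 nM
compound 2 `O=C([C@@H]1CCCN1)N1CCN(c2nc(NCc3ccc(Cl)cc3Cl)c3cccnc3n2)CC1` 80 nM

Both numbers come from an assay on HEK293 cells for displacement of a labelled ligand from C-C chemokine receptor type 4 (Homo sapiens); a higher number here means a weaker inhibitor, a lower number a stronger inhibitor. Compound 1 gives the highest of the two values; compound 2 gives the lower number, a gap beyond the scatter. Compound 3 `CCN(CC)CCCC(C)Nc1nc(NCc2ccc(Cl)cc2Cl)nc2nc[nH]c12` is not yet measured. It differs from compound 1 in one place: hydrogen in place of ethyl on an aromatic nitrogen. Among the compounds with values here, no measured pair shows this change, so its effect is uncertain; a step near the scatter in either direction is expected. The estimate for compound 3 is 3000 nM (range 900 nM to 10000 nM), a step of a 1.2-fold higher number from compound 1 to compound 3 (0.06 log units; within the scatter) expected.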

Compound 3, half-maximal inhibitory concentration: 2100 nM
The estimate for compound 3 lay 1.4-fold (0.15 log units) above the measured number; measured number inside the range.
By their numbers in this assay, from the lowest: compound 2; then compounds 3 and 1 (each within the scatter of the next).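

In this assay, putting hydrogen in place of ethyl on the aromatic nitrogen gives a 1.2-fold lower number from compound 1 to compound 3 (0.09 log units; within the scatter) and so leaves compound 1 and compound 3 indistinguishable. At this position, then, the two carbons of the ethyl can be lost without a measurable difference in this assay, and the nitrogen can carry a plain hydrogen. No other measurement offers an explanation for this result. Still open, from the compounds shown here alone, is whether a longer chain such as butyl, or a chain ending in an amine or a carboxylic acid, would be tolerated equally on this nitrogen.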